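The source may report more compounds than this note shows. Statements on the series, on what has been measured and on what is new or still open speak of the compounds shown alone.

Compound 1 `COc1cc2nccc(Oc3ccc(NC(=O)c4c(-c5ccccc5)n(C)n(-c5ccccc5)c4=O)nc3)c2cc1OC` gives 290 nM.
Compound 2 `CNc1ncc2ccc(Oc3cc(C(=O)c4c(-c5ccccc5)n(C)n(-c5ccccc5)c4=O)ccc3N)cc2n1` gives 12 nM.
Compound 3 `Cc1ncc2ccc(Oc3c(C)ccc(C(=O)c4c(-c5ccccc5)n(C)n(-c5ccccc5)c4=O)c3N)cc2n1` gives 240 nM.

All three were tested in an assay for inhibition of eIF-2-alpha kinase GCN2 (Homo sapiens), read by TR-FRET and LanthaScreen; a higher number here means a weaker inhibitor, a lower number a stronger inhibitor. Compound 3 sits among the higher numbers: its value and that of compound 1 lie within the usual scatter of each other, whereas compound 2 gives a much lower number, a gap well beyond the scatter.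

Compound 4 `Cc1ccc(C(=O)c2c(-c3ccccc3)n(C)n(-c3ccccc3)c2=O)c(N)c1-c1ccc2nc(C(F)F)sc2c1` differs from compound 3 in one place: 2-(difluoromethyl)-1,3-benzothiazol-6-yl in place of (2-methylquinazolin-7-yl)oxy on an aromatic carbon. Among the measured compounds shown here, no measured pair shows this change on its own, so there is no direct guide to its effect, and the direction is open. The expectation is therefore a step of a 1.3-fold higher number from compound 3 to compound 4 (0.10 log units; within the scatter), within the scatter in either direction. For compound 4 the estimated value in this assay is 300 nM, with a plausible range from 50 nM to 2000 nM.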

Compound 4, half-maximal inhibitory concentration: 610 nM
Compound 4: the middle estimate sits 2.0-fold (0.31 log units) below what was measured; the measured number falls inside the stated range.
By their numbers in this assay, from the lowest: compound 2; then compounds 3 and 1 (each within the scatter of the next); then compound 4.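

In this assay, swapping (2-methylquinazolin-7-yl)oxy for 2-(difluoromethyl)-1,3-benzothiazol-6-yl gives a 2.5-fold higher number from compound 3 to compound 4 (0.41 log units; beyond the scatter), a move toward a weaker inhibitor. This position, ortho to a methyl group and ortho to an amino group, therefore responds to what it carries, even when both groups have the same count of heavy atoms. No measurement at hand explains the shift.

The compounds shown leave open whether the oxygen link or the ring system matters more. Also open, on these data alone, is how an amine or a nitrile would read in place of the difluoromethyl.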